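The source may report more compounds than this note shows. Statements on the series, on what has been measured and on what is new or still open speak of the compounds shown alone.

Within the data shown here, compound 2 `COc1ccc2[nH]c(C(=O)N3CC(=O)N(Cc4ccccc4)[C@@H](CN4CC5CCCC5C4)C3)cc2c1` gives 10600 nM in an ADME assay on Vero cells (Chlorocebus sabaeus) for cytotoxicity, with a stated time of 7 days (on this read-out lower numbers stand for higher toxicity in this test and higher numbers for lower toxicity in this test), the lowest of the two numbers measured so far. Its nearest neighbour is compound 1 `COc1ccc2[nH]c(C(=O)N3CC(=O)N(Cc4ccccc4)[C@@H](CN4CCCCC4)C3)cc2c1`, which in this assay gives 76900 nM. Among the measured compounds shown here, the only measured step, a 7.3-fold lower number from compound 1 to compound 2 (0.86 log units; beyond the scatter), lies beyond the scatter and arose from exchanging the ring group on the saturated chain carbon bound to a saturated ring carbon. Compound 3 `COc1ccc2[nH]c(C(=O)N3CC(=O)N(Cc4ccccc4)[C@@H](CN4CCn5cccc5C4)C3)cc2c1` differs from compound 2 by a group of 9 heavy atoms (7 carbon, 2 nitrogen; one five-membered aromatic ring with 1 hetero atom, one six-membered non-aromatic ring with 2 hetero atoms) in place of a group of 8 heavy atoms (7 carbon, 1 nitrogen; one five-membered non-aromatic ring of carbon only, one five-membered non-aromatic ring with 1 hetero atom), on a saturated chain carbon bound to a saturated ring carbon. The step from compound 1 to compound 2 is the one that bears on this change, as it alters the same group at the same place, and it was modest in size. Because a 7.3-fold lower number from compound 1 to compound 2 (0.86 log units; beyond the scatter) showed that the group at this place shifts the number, a further shift beyond the scatter is expected, most likely back toward the higher number. Compound 3 is therefore expected to show a step of a 2.8-fold higher number from compound 2 to compound 3 (0.45 log units; beyond the scatter), with an estimated value of 30000 nM in this assay, in a range from 8000 nM to 110000 nM.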

Compound 3, half-maximal cytotoxic concentration: > 100000 nM
Compound 3 ended at the assay's limit; the forecaster's own chance of this, stated with the estimate: 20%; middle value at least 3.3-fold (0.52 log units) away from the limit.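

In this assay the reading of compound 3 is a limit of the assay and not a number: the limit of > 100000 nM in this assay, at which 1 of the 3 values shown sits. Even so, this change gives an at least 9.4-fold higher number from compound 2 to compound 3 (0.97 log units; beyond the scatter), so the group on the saturated chain carbon bound to a saturated ring carbon can move the number upward as well as downward, and the group with the five-membered aromatic ring does not share the lower number of compound 2. The comparison with the smaller group of the first compound gives an at least 1.3-fold higher number from compound 1 to compound 3 (0.11 log units; that floor lies within the scatter), so that pair cannot be put in order.

The compounds shown do not separate the part played by the aromatic ring from that of the second nitrogen in the entering group. On these data alone, it also stays open how a morpholine or a dimethylamino group would read at this place.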